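Will Isopropyl Shift Cell Tolerance in This Series?

The compounds below may be only part of what the source reports. "The series", "measured", "known", "first", "only" and "open" are said of these compounds alone.

Compound 2 `CCCCC1C(=O)N(O)C(=O)c2ccccc21` stands level with compound 1 `CCCC1C(=O)N(O)C(=O)c2ccccc21` in an ADME assay on MT4 cells (Homo sapiens) for cytotoxicity, read by MTT assay; a lower number here means that less compound is tolerated, a higher number that more compound is tolerated. Compound 1 gives 25400 nM, and compound 2 gives 25400 nM. Going by the values given here, only one measured step connects them: no change at the digits printed from compound 1 to compound 2 (within the scatter). That step puts a methyl in place of hydrogen on a saturated chain carbon, three bonds along the chain from a saturated ring carbon.

The next compound, compound 3 `CC(C)C1C(=O)N(O)C(=O)c2ccccc21`, changes the same group. It has isopropyl in place of butyl on a saturated ring carbon, two ring bonds from the ring nitrogen. Among the compounds with values here, no compound measured so far carries isopropyl, so the data offer only an indirect guide to this swap.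

Within the data shown here, that guide is the single step of no change at the digits printed from compound 1 to compound 2 (within the scatter), which also altered the group on this ring carbon and left this assay unmoved. On that evidence, no shift beyond the scatter is expected in either direction. The expected step is no change at the digits printed from compound 2 to compound 3 (within the scatter). For compound 3 the estimated value is 25400 nM, with an expected range of 12000 nM to 50000 nM.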

Compound 3, half-maximal cytotoxic concentration: 123000 nM
Estimate against measurement, compound 3: 4.8-fold (0.69 log units) below; measured number above the stated range.
By their numbers in this assay, from the lowest: compounds 1 and 2 (each within the scatter of the next); then compound 3.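

Swapping butyl for isopropyl on this saturated ring carbon gives a 4.8-fold higher number from compound 2 to compound 3 (0.69 log units; beyond the scatter) in this assay and so more compound is tolerated, while swapping propyl for isopropyl gives a 4.8-fold higher number from compound 1 to compound 3 (0.69 log units; beyond the scatter) in the same read-out. The earlier pair showed only that lengthening a straight chain from propyl to butyl leaves the number unmoved, which could have suggested that the group on this carbon hardly matters; the new result shows that it can matter, and that the shape of the group counts here, not only its length, since the same rise appears from either straight chain and all three compounds fit this reading. Nothing measured here explains why the branched group stands apart from the two straight chains.

Going by these compounds alone, with only one branched group in hand, it remains open whether branching itself goes with the higher number or whether isopropyl is a special case, which a tert-butyl or cyclopropyl group on this ring carbon could help to settle. As far as these compounds go, it is also open whether a shorter straight chain, such as ethyl, would stay level with propyl and butyl or move towards isopropyl.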